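The source may report more compounds than this note shows. Statements on the series, on what has been measured and on what is new or still open speak of the compounds shown alone.

The account follows three amino-alcohol compounds that share a long saturated chain. Compound 1, with the structure `CCCCCCCCCCCCCCC(CO)NC(=O)CCCC(=O)OC`, carries a methyl ester amide at the amine; in an ADME assay on cells (Splenocyte, Mus musculus, strain BALB/c) for cytotoxicity, read by MTT assay, tested at 1 ug/mL (on this read-out lower numbers stand for a weaker effect and higher numbers for a stronger effect at the one concentration tested), compound 1 is recorded as "not determined" (no result reported), with no result reported. Compound 2, with the structure `CCCCCCCCCCCCCCC(CO)N(CC)CC`, is the only one of the three with a number: in this assay compound 2 gives 7.5%, and with the other entry lacking a number, this is where compound 2 stands. Compound 3, with the structure `CCCCCCCCCCCCCCC(CO)NCCCCCC`, has not yet been tested in this assay. It differs from compound 2 in one place: hexylamino in place of diethylamino on a saturated chain carbon bound to two saturated chain carbons. Among the compounds with values here, no measured pair in this set differs by a single change, so nothing here shows how large a step such a swap produces in this assay. The step from compound 2 to compound 3 is therefore expected to be small, in no firm direction, and not clearly beyond the usual scatter, as a number 2.5 percentage points higher from compound 2 to compound 3 (within the scatter). Compound 3 is accordingly estimated at 10% in this assay, with a range from 0% to 25%.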

Compound 3, a percentage reported as activity, at one concentration (the size of the read-out at that concentration, not a potency): 5%
For compound 3 the middle estimate is 5 percentage points above the measured one, and the stated range covers the measured number.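

In this assay, within the data shown here, hexylamino in place of diethylamino on a saturated chain carbon bound to two saturated chain carbons gives a number 2.5 percentage points lower from compound 2 to compound 3 (within the scatter); this is the first step in the set that can be read at this position. Hexylamino brings a hydrogen-bond donor that diethylamino lacks, and it has more heavy atoms, yet this exchange leaves the values of the two compounds within the scatter of each other, so the read-out does not tell these two amines apart at the one concentration tested. No accompanying measurement bears on this result, so it rests on the pair of values alone.

In this assay compound 1 gives "not determined" (no result reported), so the amide carrying the methyl ester cannot be set against either amine. As far as these compounds go, it also remains open whether a primary amine, a dihexylamino group, a piperidine ring or a carboxylic acid in place of the methyl ester would give a step beyond the scatter in this assay at this position.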